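A few compounds are considered here, and "the series" means these few. Any claim that something is new, unique, unknown or untested is made for them only; others in the source may bear on it.

Compound 1 `Nc1cccc(Nc2c(C(=O)NCc3ccc(F)cc3)nc(Br)c3cccnc23)c1` gives > 10000 nM
Compound 2 `NCCCNc1c(C(=O)NCc2ccc(F)cc2)nc(Br)c2cccnc12` gives "not determined" (no result reported)

Compound 2 has no number in a functional assay on HT-29 cells (Homo sapiens) for cytotoxicity, read by MTT assay, with a stated time of 72 h (on this read-out lower numbers stand for stronger inhibition and higher numbers for weaker inhibition), and carries only "not determined" (no result reported) as its entry. Compound 1 stands at > 10000 nM as a limit and not as a number. Compound 3 `Nc1ccc(Nc2c(C(=O)NCc3ccc(F)cc3)nc(Br)c3cccnc23)cc1` differs from compound 2 as 4-aminophenyl in place of 3-aminopropyl on a nitrogen on an aromatic ring and puts 4-aminophenyl in place of 3-aminopropyl on a nitrogen on an aromatic ring. With no number for compound 2, no size or direction of this step in this assay can be read from the data, so none beyond the scatter is expected. Compound 3 is estimated at 8000 nM with 2000 nM and 30000 nM as the expected ends of its range.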

Compound 3, half-maximal inhibitory concentration: > 10000 nM
Compound 3 was reported as a limit (the forecaster's own chance of this, stated with the estimate: 55%); middle value at least 1.2-fold (0.09 log units) from the limit.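

For the compounds shown here, no step from compound 1 to compound 3 can be read in this assay, because both compounds are reported only as limits and not as numbers: the limit of > 10000 nM in this assay, at which 2 of the 3 values shown sit. The compounds shown leave open whether 3-aminophenyl and 4-aminophenyl differ at all on this read-out, and how 3-aminopropyl compares with either.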